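Swapping a cyclopropylamino for methoxy on a pyrazine-like core

The compounds below may be only part of what the source reports. "The series", "measured", "known", "first", "only" and "open" are said of these compounds alone.

Measured compounds:
- compound 1, `NC(N)=NC(=O)c1nc(Cl)c(NC2CC2)nc1N`: "not determined" (no result reported) in an assay for inhibition of acid-sensing ion channel 3 (Homo sapiens), read by patch clamp, tested at 1 uM; a lower number here means less inhibition, a higher number more inhibition at the concentration tested (going by the name of the read-out)
- compound 2, `NC(N)=NC(=O)c1nc(Cl)c(NCC2CCCCC2)nc1N`: 28%
- compound 3, `NC(N)=NC(=O)c1nc(Cl)c(N2CCc3ccccc32)nc1N`: 46%

Three compounds share a core that carries a chloro group, an amino group and an acylguanidine-type side chain, and differ only in the group on the remaining ring carbon. As far as these compounds go, for compound 1, which carries a cyclopropylamino group there, the result in this assay is "not determined" (no result reported), so its own standing is unknown. Compound 2 carries a larger cyclohexylmethylamino group and gives 28%. Compound 3, with a fused bicyclic amine at that position, gives 46%. Both numbers describe how much the channel response is reduced at a single concentration, that is, the strength of the effect at that concentration.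

The step from compound 1 to compound 4, `COc1nc(N)c(C(=O)N=C(N)N)nc1Cl`, is this: methoxy in place of cyclopropylamino on an aromatic carbon. The new group is smaller and loses the hydrogen-bond donor that the amine carried.

Going by the values given here, with no measured pair that isolates this kind of change, only a rough expectation is possible: a modest shift in this assay, if any, most likely downward relative to the two measured neighbours, and it could well stay within the ordinary scatter. Compound 4 is expected to give about 20%, with a plausible range from 5% to 40%.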

Compound 4, a percentage reported as inhibition, at one concentration (the size of the read-out at that concentration, not a potency): 21%
Estimate against measurement, compound 4: 1 percentage points below; measured number inside the range.
By their numbers in this assay, from the lowest: compounds 4 and 2 (each within the scatter of the next); then compound 3.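

In this assay compound 1 reads "not determined" (no result reported) and compound 4 reads 21% so the swap of cyclopropylamino for methoxy between these two compounds cannot be read as a step. What the compounds shown leave open is how far, if at all, that swap shifts inhibition. Nothing further here bears on the result of compound 4.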